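Swapping a Bromofuran for a Trifluoromethyl Oxazole

A few compounds are considered here, and "the series" means these few. Any claim that something is new, unique, unknown or untested is made for them only; others in the source may bear on it.

Compound 1 `CC(C)C[C@@H]1C(=O)N[C@H](C2Cc3ccccc3C2)C(=O)N1[C@@H](C(=O)NC(C)C)c1ccc(Br)o1` is one of two measured members of a shared core. In an assay on isolated protein for binding affinity to Oxytocin receptor (Homo sapiens) (a higher number here means a weaker inhibitor, a lower number a stronger inhibitor), compound 1 gives 0.794 nM, and compound 2 `CC(C)C[C@@H]1C(=O)N[C@H](C2Cc3ccccc3C2)C(=O)N1[C@@H](C(=O)N(C)C)c1coc(C2CC2)n1` gives 0.794 nM in this assay, so compound 1 stands level with compound 2 at the digits shown, within the scatter.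

Compound 3 `CC(C)C[C@@H]1C(=O)N[C@H](C2Cc3ccccc3C2)C(=O)N1[C@@H](C(=O)NC(C)C)c1coc(C(F)(F)F)n1` has not been measured. From compound 1 it differs in one place: a group of 9 heavy atoms (4 carbon, 1 nitrogen, 1 oxygen, 3 fluorine; one five-membered aromatic ring with 2 hetero atoms) in place of a group of 6 heavy atoms (4 carbon, 1 oxygen, 1 bromine; one five-membered aromatic ring with 1 hetero atom), on a saturated chain carbon bound to an amide-type nitrogen in a ring and a carbonyl carbon. Compound 2 already carries a five-membered aromatic ring with two hetero atoms at this position and is level with compound 1, so no step beyond the scatter in either direction is expected from compound 1 to compound 3 in this assay. Compound 3 is accordingly expected to give about 1 nM in this assay, with a plausible range from 0.3 nM to 3.5 nM, which corresponds to an estimated step of a 1.3-fold higher number from compound 1 to compound 3 (0.10 log units; within the scatter).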

Compound 3, inhibition constant: 0.159 nM
Compound 3: the middle estimate sits 6.3-fold (0.80 log units) above what was measured; measured number below the stated range.
By their numbers in this assay, from the lowest: compound 3; then compounds 1 and 2 (each within the scatter of the next).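

In this assay, the group on the saturated chain carbon bound to an amide-type nitrogen in a ring and a carbonyl carbon turns out to matter: replacing 5-bromofuran-2-yl with the trifluoromethyl oxazole gives a 5.0-fold lower number from compound 1 to compound 3 (0.70 log units; beyond the scatter) in the number, a step beyond the scatter. Going by these compounds alone, compound 1 and compound 2 differ in more than one place, so this is the first step at this position that can be read on its own. Nothing measured here accounts for the step.

The change replaces the ring and its substituent together, so the compounds shown leave open which of the two carries the step. A furan bearing trifluoromethyl or an oxazole bearing bromine would separate them, while a methyl or a carboxylic acid on the oxazole would show how far the substituent can vary.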